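A few compounds are considered here, and "the series" means these few. Any claim that something is new, unique, unknown or untested is made for them only; others in the source may bear on it.

Measured so far in an in vitro ADME assay on microsomes from liver (Rattus norvegicus) for metabolic stability; a lower number here means slower removal, a higher number faster removal of the compound:
- compound 1 `CC(C)NC(=O)[C@H]1CC[C@@H](n2/c(=N/C(=O)c3ccc(F)c(F)c3)[nH]c3ccc(CN4CCC(C(C)(C)O)CC4)cc32)CC1` gives 19 mL.min-1.g-1
- compound 2 `CC(C)NC(=O)[C@H]1CC[C@@H](n2/c(=N/C(=O)c3ccc(F)c(Cl)c3)[nH]c3ccc(CN4CCC(C(C)(C)O)CC4)cc32)CC1` gives 44 mL.min-1.g-1

Compound 2 holds the higher of these two numbers, and compound 1 lies below it by a step beyond the scatter. Moving to compound 3 `CC(C)NC(=O)[C@H]1CC[C@@H](n2/c(=N/C(=O)c3cccnc3)[nH]c3ccc(CN4CCC(C(C)(C)O)CC4)cc32)CC1` means pyridin-3-yl in place of 3-chloro-4-fluorophenyl on a carbonyl carbon on a carbonyl carbon, with pyridin-3-yl in place of 3-chloro-4-fluorophenyl. Among the measured compounds shown here, compound 3 carries no chloro, and the one measured step, a 2.3-fold higher number from compound 1 to compound 2 (0.36 log units; beyond the scatter) with chloro in place of fluoro on an aromatic carbon, was modest and upward, so a modest fall is expected in this assay here. For the measured compounds named here, the expected change is a 2.0-fold lower number from compound 2 to compound 3 (0.30 log units; within the scatter) and stays uncertain, since no measured compound carries pyridin-3-yl. For compound 3 the estimated value is 22 mL.min-1.g-1 and the expected range runs between 10 mL.min-1.g-1 and 48 mL.min-1.g-1 as its lower and upper ends.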

Compound 3, intrinsic clearance in microsomes: < 14 mL.min-1.g-1
Compound 3: a limit, no number (the forecaster's own chance of this, stated with the estimate: 2%); middle value at least 1.5-fold (0.19 log units) from the limit.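

Compound 3 gives no number in this assay, only a limit: the limit of < 14 mL.min-1.g-1 in this assay, at which 1 of the 3 values shown sits. On a carbonyl carbon, pyridin-3-yl in place of 3-chloro-4-fluorophenyl gives an at least 3.1-fold lower number from compound 2 to compound 3 (0.49 log units; beyond the scatter), so this position accepts an aromatic ring with a hetero atom and the number still falls. Against 3,4-difluorophenyl, the same replacement gives an at least 1.3-fold lower number from compound 1 to compound 3 (0.13 log units; that floor lies within the scatter), so a fall relative to that ring is not established.

On these data alone, the full size of both steps stays open behind the limit. Also open, as far as these compounds go, is how pyridin-2-yl, pyridin-4-yl or a saturated piperidine ring would read at this carbonyl carbon.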